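Working notes: from compound 2 to compound 3

A few compounds are considered here, and "the series" means these few. Any claim that something is new, unique, unknown or untested is made for them only; others in the source may bear on it.

Measured in a functional assay on SK-MEL-28 cells (Homo sapiens) for cytotoxicity, read by MTT assay, with a stated time of 3 days; on this read-out higher numbers stand for weaker inhibition and lower numbers for stronger inhibition:
- compound 1 `CCNc1nc(SCc2nc3ccccc3[nH]2)nc(-c2ccccc2)c1C#N`: 5.3 nM
- compound 2 `N#Cc1c(NC(N)=S)nc(SCc2nc3ccccc3[nH]2)nc1-c1ccccc1`: 4.8 nM

Compound 2, at 4.8 nM, stands level with compound 1 within the scatter. Compound 3 `CN1CCN(c2nc(SCc3nc4ccccc4[nH]3)nc(-c3ccccc3)c2C#N)CC1` carries 4-methylpiperazin-1-yl on an aromatic carbon, ortho to a cyano group: a group of 7 heavy atoms (5 carbon, 2 nitrogen; one six-membered non-aromatic ring with 2 hetero atoms) in place of a group of 4 heavy atoms (1 carbon, 2 nitrogen, 1 sulfur; no ring), on an aromatic carbon. Among the compounds with values here, the only measured step, a 1.1-fold lower number from compound 1 to compound 2 (0.04 log units; within the scatter), lies within the scatter, but it exchanged a group on a nitrogen and involved no ring, so it guides this change only weakly. No step beyond the scatter is therefore expected in this assay, with a slight lean towards a higher number. The expected step is a 1.5-fold higher number from compound 2 to compound 3 (0.16 log units; within the scatter). Compound 3 is estimated at 7 nM, with a range of 2.5 nM to 25 nM.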

Compound 3, half-maximal inhibitory concentration: 20 nM
For compound 3 the middle estimate is 2.9-fold (0.46 log units) below the measured one, and the stated range covers the measured number.
By their numbers in this assay, from the lowest: compounds 2 and 1 (each within the scatter of the next); then compound 3.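

In this assay this aromatic carbon, ortho to a cyano group, now shows a change beyond the scatter: a 4.2-fold higher number from compound 2 to compound 3 (0.62 log units; beyond the scatter) and a 3.8-fold higher number from compound 1 to compound 3 (0.58 log units; beyond the scatter) on bringing in 4-methylpiperazin-1-yl. Within the data shown here, compound 1 and compound 2 had stood level, so the number had not yet been seen to respond to the group at this carbon. Among these compounds, the ring-bearing group of compound 3 is the first to depart from that level, and the departure is modest.

Open, on these data alone, is whether morpholin-4-yl or an open-chain dimethylamino group on this carbon would stay level with compound 1 and compound 2 or track compound 3. No measurement at hand bears on what lies behind this result.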